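Dimethylamino in place of the acetamidoethylamino chain on the shared core

This account rests on a few compounds, and the source may have more. Where it says the series, first, only, none or still open, it means among the compounds named here.

Of the compounds shown here, three built on the same diaryl ether core have been measured in a functional assay on SW-620 cells (Homo sapiens) for inhibition, read by MTT assay, with a stated time of 72 h; a lower number here means a stronger inhibitor, a higher number a weaker inhibitor. Compound 1 `COc1ccc(CCCNCc2c(OC)cc(Oc3ccc(Nc4ccccc4)cc3)cc2OC)cc1` gives 14600 nM, compound 2 `CNCc1c(OC)cc(Oc2cccc(Nc3ccccc3)c2)cc1OC` gives 15000 nM, and compound 3 `COc1cc(Oc2cccc(Nc3ccccc3)c2)cc(OC)c1CNCCNC(C)=O` gives 11900 nM, the lowest of the three numbers, though it sits within the scatter of both others. Compound 4 `COc1cc(Oc2cccc(Nc3ccccc3)c2)cc(OC)c1CN(C)C` differs from compound 3 by dimethylamino in place of (2-acetamidoethyl)amino on a saturated chain carbon bound to an aromatic carbon. Within the data shown here, the one step that bears on this, a 1.3-fold lower number from compound 2 to compound 3 (0.10 log units; within the scatter), lay within the scatter, so removing the acetamidoethyl portion is expected to change little; the added methyl has no precedent here. The step from compound 3 to compound 4 in this assay is therefore expected to be a 1.1-fold higher number from compound 3 to compound 4 (0.04 log units; within the scatter). Compound 4 is estimated at 13000 nM, between 6000 nM and 30000 nM.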

Compound 4, half-maximal inhibitory concentration: > 20000 nM
Compound 4: only a limit was reported (the forecaster's own chance of this, stated with the estimate: 5%); middle value at least 1.5-fold (0.18 log units) from the limit.
By their numbers in this assay, from the lowest: compounds 3, 1 and 2 (each within the scatter of the next). At a limit, above all of these: compound 4.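

In this assay compound 4 gives > 20000 nM, which is a limit of the assay and not a number. Dimethylamino on this saturated chain carbon is thus the only change shown that leaves the shared core without a measured number, with an at least 1.6-fold higher number from compound 3 to compound 4 (0.22 log units; that floor lies within the scatter) and an at least 1.3-fold higher number from compound 2 to compound 4 (0.12 log units; that floor lies within the scatter). Both floors lie within the scatter, so neither step establishes a real loss. The compounds shown leave open how far compound 4 actually lies from compound 2 and compound 3. They also leave open how a pyrrolidine or a morpholine would read at this place.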